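The source may report more compounds than this note shows. Statements on the series, on what has been measured and on what is new or still open speak of the compounds shown alone.

Working notes on the series. Two compounds have numbers in a functional assay on HCT-116 cells (Homo sapiens) for inhibition, read by fluorescence, with a stated time of 48 h (on this read-out higher numbers stand for weaker inhibition of growth and lower numbers for stronger inhibition of growth), so far. Compound 1 `CC(C)(COC(=O)[C@@H](N)c1ccccc1)COC1(c2ccc(Cl)cc2)c2ccccc2C(=O)N1Cc1ccccc1` gives 15000 nM in this assay, the lowest of the two numbers. Compound 2 `CC(C)[C@H](N)C(=O)OCC(C)(C)COC1(c2ccc(Cl)cc2)c2ccccc2C(=O)N1Cc1ccccc1` gives 20000 nM in this assay. For the measured compounds named here, the single counted step in the set, a 1.3-fold higher number from compound 1 to compound 2 (0.12 log units; within the scatter), concerns isopropyl in place of phenyl on a saturated chain carbon bound to an amine nitrogen and a carbonyl carbon; it is the only comparison available and it stays within the scatter.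

Compound 3 `CC(C)(COC(=O)[C@@H](N)c1ccccc1)COC1(c2ccc(Cl)cc2)c2ccccc2C(=O)N1Cc1ccc(Cl)cc1` has not yet been measured in this assay. It differs from compound 1 by chloro in place of hydrogen on an aromatic carbon, the chloro entering on an aromatic carbon of a six-membered aromatic ring of carbon only, benzyl becoming 4-chlorobenzyl. Going by the values given here, no measured step in the set touches that aromatic ring; the one step that exists, from compound 1 to compound 2, sits on the chain carbon and was within the scatter. With nothing to point in either direction, no step beyond the scatter is expected for compound 3 in this assay, that is no change at the digits printed from compound 1 to compound 3 (within the scatter). Compound 3 is therefore estimated at 15000 nM, with a range from 6000 nM to 40000 nM.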

Compound 3, concentration for 50% growth inhibition: 8000 nM
Compound 3: middle estimate off by 1.9-fold (0.27 log units), on the high side; the range from low to high includes it.
By their numbers in this assay, from the lowest: compounds 3, 1 and 2 (each within the scatter of the next, the first and the last beyond it).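

For the compounds shown here, this is the first change on the aromatic ring of the benzyl group: in this assay, benzyl becoming 4-chlorobenzyl gives a 1.9-fold lower number from compound 1 to compound 3 (0.27 log units; within the scatter) and so stays within the usual scatter. The ring therefore accepts a chloro on this aromatic carbon, para to a large group, without a step beyond the scatter, and the earlier step on the chain carbon could not show this. No information bears on what lies behind this result.

The compounds shown leave open whether methoxy, trifluoromethyl, an amine or a carboxylic acid on this same aromatic carbon would give a step beyond the scatter, or whether a chloro elsewhere on the ring would do so. Going by these compounds alone, they also leave open whether 4-chlorobenzyl would give a similar step with isopropyl on the chain carbon, as in compound 2, since the phenyl to isopropyl change and the hydrogen to chloro change are each seen only on their own, from compound 1.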